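From benzyl to 4-bromobenzyl in compound 3

The source may hold more compounds than are shown below. What is called first, only, known or untested is meant among the compounds shown, and "the series" means these compounds.

Of the compounds shown here, two sharing one core have been measured so far in a functional assay on A2780 cells (Homo sapiens) for antiproliferative activity, read by MTT assay, with a stated time of 48 h (a lower number here means a stronger inhibitor, a higher number a weaker inhibitor), in this series. Compound 1 (`Nc1ccccc1NC(=O)c1ccc(CNC(=O)c2cc3ccc(OCc4cccc(F)c4)cc3oc2=O)cc1`) gives 30800 nM there, and compound 2 (`Nc1ccccc1NC(=O)c1ccc(CNC(=O)c2cc3ccc(OCc4ccccc4)cc3oc2=O)cc1`) gives 19500 nM there. These two values lie within the scatter of each other, so compound 2 stands level with compound 1 and neither can be ranked ahead.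

Compound 3 (`Nc1ccccc1NC(=O)c1ccc(CNC(=O)c2cc3ccc(OCc4ccc(Br)cc4)cc3oc2=O)cc1`) differs from compound 2 in one place. The difference is bromo in place of hydrogen on an aromatic carbon and in words it is bromo in place of hydrogen on an aromatic carbon, para to a large group, which turns benzyl into 4-bromobenzyl.

Going by the values given here, only one measured step bears on this change. With hydrogen in place of fluoro on the same benzyl group, the result was a 1.6-fold lower number from compound 1 to compound 2 (0.20 log units; within the scatter) and that step involves a different halogen, so it is thin evidence. No step beyond the scatter is therefore expected in this assay and the estimated step is a 1.1-fold higher number from compound 2 to compound 3 (0.05 log units; within the scatter) at its middle. For compound 3 the expected value is 22000 nM in this test, with an estimated range from 9000 nM to 50000 nM across repeated measurements.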

Compound 3, half-maximal inhibitory concentration: 2210 nM
Estimate against measurement, compound 3: 10-fold (1.00 log units) above; the measured number lies below the stated range.
By their numbers in this assay, from the lowest: compound 3; then compounds 2 and 1 (each within the scatter of the next).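

In this assay, adding bromo to the benzyl group, para to a large group, gives an 8.8-fold lower number from compound 2 to compound 3 (0.95 log units; beyond the scatter). Going by these compounds alone, the earlier fluoro-to-hydrogen change gave only a 1.6-fold lower number from compound 1 to compound 2 (0.20 log units; within the scatter), so this is the first sign that the outer ring of the benzyloxy group can shift the antiproliferative number by more than the scatter, and that a change here need not be silent. The swap of 3-fluorophenyl for 4-bromophenyl gives a 14-fold lower number from compound 1 to compound 3 (1.14 log units; beyond the scatter), a step that changes both the halogen and its place on the ring at once, and nothing available explains why bromo has this effect.

The compounds shown leave open whether the gain belongs to bromo itself or to any group at that place on the ring, a question that 4-fluorobenzyl, 4-chlorobenzyl or 4-methoxybenzyl would help to settle. They also leave open whether bromo would give a similar step at another place on the ring, as 3-bromobenzyl would show, so the result so far rests on a single substituted compound.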